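The source may report more compounds than this note shows. Statements on the series, on what has been measured and on what is new or still open speak of the compounds shown alone.

Measured so far:
- compound 1, `COc1ccc(-c2cc(/C=C/C(=O)c3ccc(N)cc3)[nH]n2)cc1`: 97%
- compound 2, `COc1cc(-c2cc(/C=C/C(=O)c3ccc(Cl)c(Cl)c3)[nH]n2)cc(OC)c1OC`: 103%

In a functional assay on COLO 205 cells (Homo sapiens) for cytotoxicity, read by sulforhodamine B assay, with a stated time of 48 h, tested at 0.01 uM (a higher number here means a weaker effect of the compound at the concentration tested, a lower number a stronger effect), compound 1 gives 97%, and compound 2 gives 103%. Compound 2 holds the higher of the two numbers, but the gap to compound 1 is within the scatter, so the two compounds cannot be told apart on this read-out; both show essentially no effect at the concentration tested. Going by the values given here, no step between compounds differing in a single place is available, so the size of any structural change on this assay is untested.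

Compound 3, `COc1cc(-c2cc(/C=C/C(=O)c3ccc(F)c(F)c3)[nH]n2)cc(OC)c1OC`, is the next compound to be measured in this assay. It differs from compound 2 in one place: 3,4-difluorophenyl in place of 3,4-dichlorophenyl on a carbonyl carbon. Among the compounds with values here, with no measured step to lean on and both measured compounds sitting at full activity, a change no larger than the scatter is expected from compound 2 to compound 3, a number 3 percentage points lower from compound 2 to compound 3 (within the scatter), in no particular direction. Compound 3 is estimated at 100% in this assay, within a range of 85% to 115%.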

Compound 3, a percentage reported as activity, at one concentration (the size of the read-out at that concentration, not a potency): 101%
The estimate for compound 3 lay 1 percentage points below the measured number; low and high end bracket the measured number.
By their numbers in this assay, from the lowest: compounds 1, 3 and 2 (each within the scatter of the next).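

In this assay the series now has its first step in a single place, a number 2 percentage points lower from compound 2 to compound 3 (within the scatter), so compound 2 and compound 3 cannot be told apart when 3,4-difluorophenyl stands in place of 3,4-dichlorophenyl on a carbonyl carbon. Exchanging chlorine for fluorine in this group therefore produces no readable effect on this read-out at the single concentration tested, although both compounds show essentially no effect, so the comparison has little room to reveal a difference. No measurement is available that bears on this result.

From the compounds shown here alone, whether this position would respond to a different kind of group, such as a carboxylic acid or a morpholine in place of the 3,4-difluorophenyl, remains open. The shown compounds also leave open whether compound 2 and compound 3 would differ in a read-out that gives a potency.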